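Swapping a dimethoxypyrimidine for bromophenyl: cytotoxicity outlook

This account rests on a few compounds, and the source may have more. Where it says the series, first, only, none or still open, it means among the compounds named here.

Compound 1 `CC(C)N(Cc1cccc(OCCCCCC(=O)O)c1)C(=O)c1ccc(-c2c[nH]c3ccccc23)cc1` gives > 26000 nM in an ADME assay on HepG2 cells (Homo sapiens) for cytotoxicity, read by CellTiter-Glo and resazurin assay, with a stated time of 72 h (on this read-out lower numbers stand for an effect already at smaller amounts and higher numbers for an effect only at larger amounts of compound), which is a limit of the assay rather than a number.
Compound 2 `CCOC(=O)CCCCCOc1cccc(CN(C(=O)c2ccc(-c3cnc(OC)nc3OC)cc2)C(C)C)c1` gives > 26000 nM in this assay, again only a limit.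
Compound 3 `CCOC(=O)CCCCCOc1cccc(CN(C(=O)c2ccc(-c3cn(S(=O)(=O)c4ccccc4)c4ccccc34)cc2)C(C)C)c1` gives > 26000 nM in this assay, also only a limit.

Compound 2 thus stands where every measured compound stands, at the limit (the limit of > 26000 nM in this assay, at which 3 of the 3 values shown sit), with no number of its own. Compound 4 `CCOC(=O)CCCCCOc1cccc(CN(C(=O)c2ccc(-c3cccc(Br)c3)cc2)C(C)C)c1` differs from compound 2 in one place (3-bromophenyl in place of 2,4-dimethoxypyrimidin-5-yl on an aromatic carbon). Within the data shown here, no measured pair shows a change of this kind, so the data give no step size to lean on. Since all three values sit at the limit (the limit of > 26000 nM in this assay, at which 3 of the 3 values shown sit), compound 4 is expected to stay there too, the expected step that the limit leaves unreadable from compound 2 to compound 4 being none beyond the scatter. Compound 4 is therefore estimated at 30000 nM, within 15000 nM to 60000 nM.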

Compound 4, half-maximal effective concentration: > 26000 nM
Compound 4: a limit, no number; the forecaster's own chance of this, stated with the estimate: 80%; the middle value is on the limit's open side.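

No step can be read from compound 2 to compound 4, since both values are only limits: the limit of > 26000 nM in this assay, at which 4 of the 4 values shown sit.

The compounds shown leave open what concentration, if any, would give a measurable effect in this assay.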